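The source may hold more compounds than are shown below. What is called first, only, known or untested is meant among the compounds shown, and "the series" means these compounds.

Measured so far in an ADME assay on HEK293 cells (Homo sapiens) for cytotoxicity, read by resazurin assay, with a stated time of 48 h; on this read-out higher numbers stand for lower toxicity in this test and lower numbers for higher toxicity in this test:
Compound 1 `O=S(=O)(Nc1ccc2oc(-c3ccccc3)nc2c1)c1cccc(C(F)(F)F)c1` — in this assay compound 1 gives > 100000 nM, which is a limit of the assay and not a number.
Compound 2 `O=S(=O)(Nc1ccc2oc(-c3ccccc3)nc2c1)c1cccc(Cl)c1` — in this assay compound 2 gives 70000 nM.
Compound 3 `CCc1ccc(S(=O)(=O)Nc2ccc(-c3nc4ccccc4o3)cc2)cc1` — in this assay compound 3 gives 82000 nM.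

Compound 2 holds the lowest of the two numbers shown, and its nearest neighbour, compound 3, lies within the usual scatter of it, so no order between the two can be read. For the measured compounds named here, only one measured step changes the group on the sulfonyl sulfur: an at least 1.4-fold lower number from compound 1 to compound 2 (0.15 log units; that floor lies within the scatter). Compound 1 stands at the limit of > 100000 nM in this assay, at which 1 of the 3 values shown sits. The unmeasured compound 4 `O=S(=O)(Nc1ccc2oc(-c3ccccc3)nc2c1)c1ccc(Cl)s1` differs from compound 2 by 5-chlorothiophen-2-yl in place of 3-chlorophenyl on a sulfonyl sulfur. The step from compound 1 to compound 2 is the only one that bears on this change, and its floor sits within the scatter; no step beyond the scatter is expected in this assay in either direction. Compound 4 is accordingly estimated at 70000 nM, with a range from 35000 nM to 140000 nM. This estimate means an expected step of no change at the digits printed from compound 2 to compound 4 (within the scatter).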

Compound 4, half-maximal cytotoxic concentration: > 100000 nM
Compound 4 gave a limit, no number; the forecaster's own chance of this, stated with the estimate: 30%; middle value at least 1.4-fold (0.15 log units) away from the limit.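

In this assay the exchange of 3-chlorophenyl for 5-chlorothiophen-2-yl on a sulfonyl sulfur gives an at least 1.4-fold higher number from compound 2 to compound 4 (0.15 log units; that floor lies within the scatter), so this place can hold a five-membered aromatic ring with 1 hetero atom with no drop in the number, though no rise can be claimed either. Compound 4 gives > 100000 nM, which is a limit of the assay and not a number. With this result a second group on the sulfonyl sulfur reaches that limit, so compound 1 and compound 4 cannot be ordered against each other: the limit of > 100000 nM in this assay, at which 2 of the 4 values shown sit.

From the compounds shown here alone, how far the number of compound 4 lies from that of compound 2 stays open, since only a floor is known. The compounds shown also leave open what a thiophene without chlorine, or an amine or a carboxylic acid on the ring at this place, would give.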